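A few compounds are considered here, and "the series" means these few. Any claim that something is new, unique, unknown or untested is made for them only; others in the source may bear on it.

Compound 1 `O=C1NCCN1c1ccc(S(=O)(=O)Nc2ccc(OC(F)F)cc2)cc1` gives 760 nM in a functional assay on MCF7 cells (Homo sapiens) for antiproliferative activity, read by sulforhodamine B assay, with a stated time of 48 h (on this read-out lower numbers stand for stronger inhibition and higher numbers for weaker inhibition), the second highest of the three numbers measured. Compound 2 `CCCCOc1ccc(NS(=O)(=O)c2ccc(N3CCNC3=O)cc2)cc1` gives 870 nM in this assay, and compound 3 `COc1cccc(NS(=O)(=O)c2ccc(N3CCNC3=O)cc2)c1` gives 120 nM. The step from compound 1 to compound 4 `O=C1NCCN1c1ccc(S(=O)(=O)Nc2ccc(F)cc2)cc1` is fluoro in place of difluoromethoxy on an aromatic carbon. Within the data shown here, the only measured step at the same aromatic carbon, a 1.1-fold higher number from compound 1 to compound 2 (0.06 log units; within the scatter), kept the oxygen and changed what sits on it, so it bears on the new step only loosely; compound 3 has a different group at a different place and its value is not a guide. Among the measured compounds shown here, no measured step exceeds the scatter here, so compound 4 is expected to show no step beyond the scatter, a 1.0-fold lower number from compound 1 to compound 4 (0.01 log units; within the scatter), and is estimated at 750 nM in this assay, between 250 nM and 2200 nM.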

Compound 4, half-maximal inhibitory concentration: 690 nM
For compound 4 the middle estimate is 1.1-fold (0.04 log units) above the measured one; the range from low to high includes it.
By their numbers in this assay, from the lowest: compound 3; then compounds 4, 1 and 2 (each within the scatter of the next).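

In this assay the steps of a 1.1-fold lower number from compound 1 to compound 4 (0.04 log units; within the scatter) and a 1.3-fold lower number from compound 2 to compound 4 (0.10 log units; within the scatter) show that this aromatic carbon, para to a large group, takes fluoro as readily as difluoromethoxy or butoxy, so the oxygen on it is not needed to keep the number. The step of a 5.8-fold higher number from compound 3 to compound 4 (0.76 log units; beyond the scatter) is beyond the scatter, but it changes both the group and its place, so it cannot separate the two. Nothing shown explains these values.

As far as these compounds go, whether an amine or a carboxylic acid on this carbon would also leave the number unchanged remains open, as does whether fluoro at the place of the methoxy in compound 3 would keep its lower number.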